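The compounds below may be only part of what the source reports. "The series", "measured", "known", "first", "only" and "open" are said of these compounds alone.

Series notes. In an assay on MDA-MB-231 cells for displacement of a labelled ligand from C-X-C chemokine receptor type 4 (Homo sapiens), read by fluorescence and microscopy, with stated times of 10 min and 30 min (a lower number here means that less compound is needed, a higher number that more compound is needed for the effect), compound 1 `Cc1cccc(S(=O)(=O)NCc2ccc(CNC(=O)c3cccnc3)cc2)c1` gives 10 nM; compound 2 `COc1ccccc1C(=O)NCc1ccc(CNS(=O)(=O)c2cccc(C)c2)cc1` gives 1000 nM; compound 3 `O=C(NCc1ccc(CNS(=O)(=O)c2ccccc2F)cc1)c1cccnc1` gives 100 nM. Compound 2 carries the highest number of the three measured: a 100-fold higher number from compound 1 to compound 2 (2.00 log units; beyond the scatter), and compound 3 sits between, a 10-fold higher number from compound 1 to compound 3 (1.00 log units; beyond the scatter). Compound 4 `COc1ccccc1C(=O)NCc1ccc(CNS(=O)(=O)c2cccc(Cl)c2)cc1` is not yet measured. It differs from compound 2 by chloro in place of methyl on an aromatic carbon, the (3-methylphenyl)sulfonyl becoming (3-chlorophenyl)sulfonyl. Among the measured compounds shown here, no measured step makes this exchange. For the measured compounds named here, the only step that alters the group on the sulfonyl sulfur is a 10-fold higher number from compound 1 to compound 3 (1.00 log units; beyond the scatter), which is modest, while a 100-fold higher number from compound 1 to compound 2 (2.00 log units; beyond the scatter) concerns the carbonyl carbon instead. A step of at most that modest size, in no firm direction, is therefore expected. Compound 4 is estimated at 1000 nM, within 300 nM to 4000 nM. The expected no change at the digits printed from compound 2 to compound 4 (within the scatter) should stay within the scatter.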

Compound 4, effective concentration (reported as EC, without a stated level of effect): 1000 nM
Estimate against measurement, compound 4: no gap at the digits printed, within the range that was stated.
By their numbers in this assay, from the lowest: compound 1; then compound 3; then compounds 2 and 4 (each within the scatter of the next).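

In this assay the exchange of methyl for chloro on the aromatic carbon gives no change at the digits printed from compound 2 to compound 4 (within the scatter) and so leaves the number in place with the 2-methoxyphenyl amide. The earlier step on the sulfonyl sulfur, a 10-fold higher number from compound 1 to compound 3 (1.00 log units; beyond the scatter), replaced the whole 3-methylphenyl group, whereas this one alters only the group on that ring. Nothing at hand gives a reason for this result.

Going by these compounds, it remains open whether the same exchange stays flat with the pyridin-3-yl amide of compound 1, where the number is lower. On these data alone, how a carboxylic acid or a dimethylamino group would fare at this position also remains open.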